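A few compounds are considered here, and "the series" means these few. Any claim that something is new, unique, unknown or untested is made for them only; others in the source may bear on it.

Measured in a functional assay on MCF7 cells (Homo sapiens) for inhibition, read by sulforhodamine B assay; on this read-out higher numbers stand for weaker inhibition and lower numbers for stronger inhibition:
- Compound 1 `COc1ccc(NC2=CC(=O)c3nc4n(c3C2=O)[C@H]2OC[C@@H](O)[C@H]2OC4)cc1`: 5420 nM
- Compound 2 `O=C1C=C(Nc2ccccc2)C(=O)c2c1nc1n2[C@H]2OC[C@@H](O)[C@H]2OC1`: > 4000 nM
- Compound 3 `O=C1C=C(Nc2cccc(Cl)c2)C(=O)c2c1nc1n2[C@H]2OC[C@@H](O)[C@H]2OC1`: 4720 nM

The entry for compound 2 is a limit of the assay, not a number. Among the compounds with values here, only two numbers can therefore be compared, and the gap between them is a 1.1-fold lower number from compound 1 to compound 3 (0.06 log units; within the scatter). Compound 3 thus stands level with compound 1. The other two steps, a step that the limit leaves unreadable from compound 1 to compound 2 and a step that the limit leaves unreadable from compound 2 to compound 3, have no readable size.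

Compound 4 `O=C1C=C(N2CCCC2)C(=O)c2c1nc1n2[C@H]2OC[C@@H](O)[C@H]2OC1` has not yet been measured. It carries pyrrolidin-1-yl in place of (3-chlorophenyl)amino on a double-bonded ring carbon. Every measured compound keeps a phenyl ring on an amine nitrogen, so the measured steps bear on this change only indirectly. Within the data shown here, the single readable step stayed within the scatter, so no step beyond the scatter is expected in this assay, in either direction, though this expectation is loose. The expected size is a 1.1-fold higher number from compound 3 to compound 4 (0.03 log units; within the scatter). Compound 4 is estimated at 5000 nM, with an expected range of 1800 nM to 14000 nM.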

Compound 4, half-maximal inhibitory concentration: > 16000 nM
Compound 4: no number, only a limit; the forecaster's own chance of this, stated with the estimate: 30%; middle value at least 3.2-fold (0.50 log units) from the limit.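

Within the data shown here, replacing (3-chlorophenyl)amino with pyrrolidin-1-yl on this double-bonded ring carbon is the first change in this assay that reaches beyond the scatter, with an at least 3.3-fold higher number from compound 3 to compound 4 (0.53 log units; beyond the scatter) and an at least 2.9-fold higher number from compound 1 to compound 4 (0.47 log units; beyond the scatter). The earlier compounds shown here showed only that 4-methoxyphenyl and 3-chlorophenyl on the amine nitrogen read level; compound 4 shows that this position is not indifferent once both the aromatic ring and the hydrogen-bond donor of the arylamino group are gone. Compound 4 carries a limit and not a number, so these steps give only a minimum size, and the steps involving the limit of compound 2 cannot be read: the limit of > 16000 nM in this assay, at which 1 of the 4 values shown sits.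

The compounds shown do not separate the aromatic ring from the amine hydrogen, since compound 4 changes both at once. A methyl(phenyl)amino group, which keeps the phenyl ring without that hydrogen, or a cyclohexylamino group, which keeps the hydrogen without the aromatic ring, would pull the two apart.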